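Selenoquinazoline series: methoxy removal on the benzyl ring

This account rests on a few compounds, and the source may have more. Where it says the series, first, only, none or still open, it means among the compounds named here.

Measured compounds:
- compound 1, `COc1ccc(CNc2nc([Se]C)nc3ccccc23)cc1` — 98600 nM
- compound 2, `COc1ccc(CNc2nc([SeH])nc3ccccc23)cc1` — 94000 nM

In a functional assay on MCF7 cells (Homo sapiens) for cytotoxicity, read by MTT assay, with a stated time of 72 h (on this read-out lower numbers stand for stronger inhibition of growth and higher numbers for weaker inhibition of growth), compound 1 gives 98600 nM and compound 2 gives 94000 nM. For the measured compounds named here, the one step between them, a 1.0-fold lower number from compound 1 to compound 2 (0.02 log units; within the scatter), leaves the two within the scatter of each other, so neither can be ordered above the other on this read-out. Compound 2 stands at the lowest of the two numbers, but only by a margin that means nothing.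

Compound 3, `[SeH]c1nc(NCc2ccccc2)c2ccccc2n1`, is not yet measured. It differs from compound 2 by hydrogen in place of methoxy on an aromatic carbon. Going by the values given here, no measured step touches this part of the molecule: the single step available, a 1.0-fold lower number from compound 1 to compound 2 (0.02 log units; within the scatter), concerns the selenium substituent and says nothing about the methoxy. Among the compounds with values here, with no bearing step, the working expectation is no change beyond the scatter, with the estimate centred on the value of compound 2.

For compound 3 the expected result in this assay is 100000 nM, with a range from 40000 nM to 250000 nM. This estimate corresponds to a step of a 1.1-fold higher number from compound 2 to compound 3 (0.03 log units; within the scatter), expected to lie within the scatter.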

Compound 3, concentration for total growth inhibition: > 100000 nM
Compound 3 ended at the assay's limit; the forecaster's own chance of this, stated with the estimate: 20%; the middle value sits exactly at the limit.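

In this assay compound 3 gives > 100000 nM, which is a limit of the assay and not a number: the limit of > 100000 nM in this assay, at which 1 of the 3 values shown sits. For the compounds shown here, the step, an at least 1.0-fold higher number from compound 2 to compound 3 (0.02 log units; that floor lies within the scatter), is the first reading at the methoxy position, on an aromatic carbon para to a large group, whereas the earlier step touched only the selenium substituent; it gives a floor and not a size, and that floor lies within the scatter. What it does show is that hydrogen in place of methoxy brings no stronger inhibition of growth beyond the scatter, so the methoxy group is not needed to hold the number where it stands, although this weak level leaves little room to judge any group.

Going by these compounds, how far the true value of compound 3 lies past the limit stays open, and so does whether losing the methoxy weakens growth inhibition at all. Also open, on these data alone, is whether an amine or a carboxylic acid on this same aromatic carbon would bring the number down into the measurable range.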